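This account rests on a few compounds, and the source may have more. Where it says the series, first, only, none or still open, it means among the compounds named here.

Measured compounds:

Compound 1, `COc1cc(-c2nc(N(C)C)sc2-c2ccc3ccccc3c2)cc(OC)c1OC`, gives 2570 nM in a functional assay on HL-60 cells (Homo sapiens) for antiproliferative activity, read by MTT assay, with a stated time of 72 h; on this read-out lower numbers stand for stronger inhibition and higher numbers for weaker inhibition.
Compound 2, `COc1cc(-c2nc(N(C)C)sc2-c2ccc(C)cc2)cc(OC)c1OC`, gives 3480 nM in this assay.
Compound 3, `COc1cc(-c2nc(C)sc2-c2ccc3ccccc3c2)cc(OC)c1OC`, gives 205 nM in this assay.

Compound 4, `COc1cc(-c2nc(C)sc2-c2ccc(C)cc2)cc(OC)c1OC`, has not yet been measured in this assay. It is related to compound 2 by the change (methyl in place of dimethylamino on an aromatic carbon). The same kind of change has been made once already, from compound 1 to compound 3, where it reads (methyl in place of dimethylamino on an aromatic carbon); that step was a 13-fold lower number from compound 1 to compound 3 (1.10 log units; beyond the scatter). The two places are not identical: in compound 1 the ring atom two bonds away bears a naphthalen-2-yl group, while in compound 2 it bears a 4-methylphenyl group. That is how the two cores differ, (4-methylphenyl in place of naphthalen-2-yl on an aromatic carbon), a change that on its own gave a 1.4-fold higher number from compound 1 to compound 2 (0.13 log units; within the scatter).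

Among the compounds with values here, because a 1.4-fold higher number from compound 1 to compound 2 (0.13 log units; within the scatter) in this assay lies within the scatter, the step from compound 2 to compound 4 is expected to resemble the one from compound 1 to compound 3, so an estimated 12-fold lower number from compound 2 to compound 4 (1.06 log units; beyond the scatter) is assumed. On that basis compound 4 is estimated at 300 nM, with an expected range from 110 nM to 850 nM.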

Compound 4, half-maximal inhibitory concentration: 1510 nM
Beside the measured number, compound 4's estimate is 5.0-fold (0.70 log units) below it; the whole stated range lies below it.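

In this assay the change to methyl in place of dimethylamino on the core of compound 2 gives a 2.3-fold lower number from compound 2 to compound 4 (0.36 log units; beyond the scatter), so the number falls on both cores and the direction of the step carries over. The size of the step does not carry over, as the two steps clearly differ: the same change on two cores in this assay, a 13-fold lower number (1.10 log units; beyond the scatter) from compound 1 to compound 3 and a 2.3-fold lower number (0.36 log units; beyond the scatter) from compound 2 to compound 4, 5.4-fold (0.74 log units) apart, beyond the scatter of two such steps
A step measured on the core bearing a naphthalen-2-yl group therefore cannot simply be transferred to the core bearing a 4-methylphenyl group, although two pairs of compounds do not show why the steps differ or what size the step would have on any other core.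

The compounds shown leave open how a plain amino group or an ethyl chain would read in place of methyl or dimethylamino on this ring carbon. They also leave open whether a further group in place of naphthalen-2-yl or 4-methylphenyl, such as 4-methoxyphenyl, would give a step closer to the larger or to the smaller one.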